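Replacing the carbamoylphenyl amide with a methylsulfonylphenyl group

This account rests on a few compounds, and the source may have more. Where it says the series, first, only, none or still open, it means among the compounds named here.

Compound 2 `NC(=O)c1ccc(C(=O)N2CCC(N(C3CC3)S(=O)(=O)c3cccc(C(F)(F)F)c3)CC2)cc1` stands lowest of the two compounds measured in an assay on cells for inhibition of Voltage-dependent L-type calcium channel subunit alpha-1C (Homo sapiens), read by FLIPR and calcium flux, tested at 1 uM (a higher number here means a stronger effect of the compound at the concentration tested, a lower number a weaker effect), where compound 2 gives 0%. Its nearest neighbour is compound 1 `O=C(c1cccc(OC(F)(F)F)c1)N1CCC(N(C2CC2)S(=O)(=O)c2cccc(C(F)(F)F)c2)CC1`, which in this assay gives 60%; the step of a number 60 percentage points lower from compound 1 to compound 2 (beyond the scatter) is beyond the scatter. Compound 3 `CS(=O)(=O)c1ccccc1C(=O)N1CCC(N(C2CC2)S(=O)(=O)c2cccc(C(F)(F)F)c2)CC1` is not yet measured; it differs from compound 2 as follows: 2-(methylsulfonyl)phenyl in place of 4-carbamoylphenyl on a carbonyl carbon. Among the compounds with values here, no measured step bears directly on this change, and the only measured step shows that the group on this carbonyl carbon can move the read-out greatly. Compound 3 is therefore expected to give 20% in this assay, between 0% and 50%, a step estimated as a number 20 percentage points higher from compound 2 to compound 3 (beyond the scatter).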

Compound 3, a percentage reported as inhibition, at one concentration (the size of the read-out at that concentration, not a potency): 19%
For compound 3 the middle estimate is 1 percentage points above the measured one, and the stated range covers the measured number.
By their numbers in this assay, from the lowest: compound 2; then compound 3; then compound 1.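

Putting 2-(methylsulfonyl)phenyl on this carbonyl carbon in this assay gives a number 19 percentage points higher from compound 2 to compound 3 (beyond the scatter), but also a number 41 percentage points lower from compound 1 to compound 3 (beyond the scatter). This position therefore supports an intermediate read-out, and among these three compounds 3-(trifluoromethoxy)phenyl stays clearly highest. Nothing available here explains the differences between these groups.

From the compounds shown here alone, it remains open whether the rise follows the methylsulfonyl group itself or the loss of the carbamoyl group. Going by these compounds, how an unsubstituted phenyl or a carboxylic acid on the phenyl ring would read at this carbonyl carbon also remains open.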